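Solubility on Moving from an Oxanyl to a Dihydroindolyl Substituent

The source may hold more compounds than are shown below. What is called first, only, known or untested is meant among the compounds shown, and "the series" means these compounds.

Measured so far:
compound 1, `CNC(=O)c1cc(C(=O)NC2CC2)cn(CC2CCCOC2)c1=O`, gives >= 131 ug/mL in a physicochemical assay for solubility; on this read-out higher numbers stand for higher solubility and lower numbers for lower solubility
compound 2, `CNC(=O)c1cc(C(=O)NCCC(C)C)cn(Cc2ccccc2)c1=O`, gives 10 ug/mL in this assay

The value for compound 1 is a limit of the assay and not a number. Compound 1 therefore stands at the limit of >= 131 ug/mL in this assay, at which 1 of the 2 values shown sits, so only the lower bound of its solubility is known. Within the data shown here, compound 2 differs from compound 1 in more than one place, and its value is the only number among the two measured compounds.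

Compound 3, `CNC(=O)c1cc(C(=O)NC2CC2)cn(Cc2cccc3c2CCN3)c1=O`, has not yet been measured in this assay. It differs from compound 1 by 2,3-dihydro-1H-indol-4-yl in place of oxan-3-yl on a saturated chain carbon bound to an aromatic nitrogen. Among the measured compounds shown here, no measured pair isolates a change of this kind, so the expectation rests on the two values shown. The step from compound 1 to compound 3 is expected to be an at least 4.3-fold lower number from compound 1 to compound 3 (0.64 log units; beyond the scatter), toward lower solubility and beyond the scatter. Compound 3 is estimated at 30 ug/mL, within a range from 8 ug/mL to 110 ug/mL.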

Compound 3, solubility: >= 184 ug/mL
Compound 3 gave a limit, no number; the forecaster's own chance of this, stated with the estimate: 15%; middle value at least 6.1-fold (0.78 log units) from the limit.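

Compound 1 and compound 3 both give limits in this assay, not numbers, so the step between them cannot be read. The compounds shown leave open how far either solubility lies past its limit, and whether 2,3-dihydro-1H-indol-4-yl in place of oxan-3-yl changes it at all.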